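Sulfonyl aryl swap on the shared core: compound 2 to compound 4

The compounds below may be only part of what the source reports. "The series", "measured", "known", "first", "only" and "open" are said of these compounds alone.

Measured compounds:
compound 1 `COc1ccc(S(=O)(=O)c2cnc3ccc(C)cc3c2N2CCC(C)CC2)cc1Cl` — 93%
compound 2 `CC1CCN(c2c(S(=O)(=O)c3ccc(C#N)cc3)cnc3cc(Cl)ccc23)CC1` — 70%
compound 3 `CC1CCN(c2c(S(=O)(=O)c3ccc(C#N)cc3)cnc3cc(F)ccc23)CC1` — 83%

Compound 2 stands lowest of the three numbers in an assay on isolated protein for displacement of a labelled ligand from metabotropic glutamate receptor 5 (Homo sapiens), with a stated time of 60 min, tested at 1 uM; on this read-out higher numbers stand for more inhibition at the one concentration tested (going by the name of the read-out) and lower numbers for less inhibition. The nearest measured compound is compound 3, reached by a number 13 percentage points higher from compound 2 to compound 3 (beyond the scatter); compound 1 stands further off, and it differs from compound 2 in more than one place, so its value is read only as a second point.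

The unmeasured compound 4 `CC1CCN(c2c(S(=O)(=O)c3ccc(Cl)c(Cl)c3)cnc3cc(Cl)ccc23)CC1` differs from compound 2 in a single place: 3,4-dichlorophenyl in place of 4-cyanophenyl on a sulfonyl sulfur. Within the data shown here, no measured step changes the group on the sulfonyl sulfur; the one step in hand, fluoro in place of chloro on an aromatic carbon, sits elsewhere on the core, and its size is modest. Compound 1, which carries a chloro-bearing aryl on the sulfonyl sulfur together with a different core substituent, gives 93%, which shows that a chlorinated aryl at this position is compatible with a high number in this assay.

Among the measured compounds shown here, with no direct precedent, the change from compound 2 to compound 4 is expected to give a step of a number 10 percentage points higher from compound 2 to compound 4 (within the scatter), a modest rise with wide uncertainty. For compound 4 the expected value in this assay is 80%, estimated to fall between 60% and 95%.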

Compound 4, a percentage reported as inhibition, at one concentration (the size of the read-out at that concentration, not a potency): 89%
Beside the measured number, compound 4's estimate is 9 percentage points below it, and the stated range covers the measured number.
By their numbers in this assay, from the lowest: compound 2; then compounds 3, 4 and 1 (each within the scatter of the next).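

In this assay, among these compounds, 3,4-dichlorophenyl in place of 4-cyanophenyl on a sulfonyl sulfur gives a number 19 percentage points higher from compound 2 to compound 4 (beyond the scatter), and this is the only step in hand that changes the group at this place. With the rest of the structure held constant, the group on the sulfonyl sulfur alone moves the read-out beyond the scatter, and the nitrile is not required for a high number at the one concentration tested, since compound 4 carries none and stands at 89% in this series. No independent data bear on why the number moves with this change, so the step stays an observation only.

The compounds shown leave open whether both chlorines are needed, and how an unsubstituted phenyl, or a phenyl carrying an amine or a carboxylic acid, would read at this place. Also open, going by these compounds, is whether the step holds on the fluoro core of compound 3, and, since the read-out comes from one concentration and is no potency, how far the sulfonyl groups differ in potency.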